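Compound 3 and the step to compound 4

The source may report more compounds than this note shows. Statements on the series, on what has been measured and on what is new or still open speak of the compounds shown alone.

Among the compounds with values here, in an ADME assay on microsomes from liver (Homo sapiens) for metabolic stability, read by LC-MS, using NADPH, with stated times of 5 min and 30 min, tested at 1 uM (a lower number here means slower removal, a higher number faster removal of the compound), compound 3 (`Cc1nccn1-c1cnc(NCc2c(F)ccc3c2CCO3)c2cn[nH]c(=O)c12`) has the lowest of the three numbers so far at 8 mL.min-1.g-1 while compound 1 (`Cn1cc(-c2cnc(NCc3c(F)ccc4c3CCO4)c3cn[nH]c(=O)c23)cn1`) gives 21 mL.min-1.g-1 and compound 2 (`Cc1ncccc1-c1cnc(NCc2c(F)ccc3c2CCO3)c2nn(CC#N)c(=O)n12`), which has a different core, gives 151 mL.min-1.g-1 as the highest. Compound 4 (`Cn1nccc1-c1cnc(NCc2c(F)ccc3c2CCO3)c2cn[nH]c(=O)c12`) has the same atoms as compound 3, joined differently (1-methyl-1H-pyrazol-5-yl in place of 2-methyl-1H-imidazol-1-yl on an aromatic carbon) on the same aromatic carbon of the shared core.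

Within the data shown here, one measured step bears on this change (a 2.6-fold lower number from compound 1 to compound 3 (0.42 log units; beyond the scatter)), a modest one that exchanged 1-methyl-1H-pyrazol-4-yl for 2-methyl-1H-imidazol-1-yl. Among the measured compounds shown here, compound 4 also carries a methylpyrazole, but as 1-methyl-1H-pyrazol-5-yl, and no measured compound has that group, so compound 1 at 21 mL.min-1.g-1 is only a rough guide to the direction. A small move to a higher number, probably within the usual scatter, is expected (a 1.8-fold higher number from compound 3 to compound 4 (0.24 log units; within the scatter)). Compound 4 is estimated at 14 mL.min-1.g-1 with an expected range of 6 mL.min-1.g-1 to 35 mL.min-1.g-1 in this assay.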

Compound 4, intrinsic clearance in microsomes: 14 mL.min-1.g-1
The estimate for compound 4 equals the measured number at the digits printed; low and high end bracket the measured number.
By their numbers in this assay, from the lowest: compounds 3, 4 and 1 (each within the scatter of the next, the first and the last beyond it); then compound 2.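

In this assay, both new steps, a 1.8-fold higher number from compound 3 to compound 4 (0.24 log units; within the scatter) and a 1.5-fold lower number from compound 1 to compound 4 (0.18 log units; within the scatter), stay within the scatter, so on this aromatic carbon, para to a large group, 1-methyl-1H-pyrazol-5-yl cannot be told apart from either 2-methyl-1H-imidazol-1-yl or 1-methyl-1H-pyrazol-4-yl. Only the earlier step, a 2.6-fold lower number from compound 1 to compound 3 (0.42 log units; beyond the scatter), lies beyond the scatter, and compound 4 now links its two ends through two steps that are each within it, so the three five-membered rings at this place span only a narrow range. Nothing measured here accounts for these numbers.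

The compounds shown leave open whether an amine or a carboxylic acid on this aromatic carbon would give a number beyond the scatter of these three. They also leave open how 1-methyl-1H-pyrazol-5-yl would read on the core of compound 2.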